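Adding Fluorine to the Benzyl Group: Compound 2 to Compound 3

The compounds below may be only part of what the source reports. "The series", "measured", "known", "first", "only" and "open" are said of these compounds alone.

Of the compounds shown here, two sharing one core have been measured in an assay for inhibition of Amine oxidase [flavin-containing] B (Rattus norvegicus); on this read-out lower numbers stand for stronger inhibition and higher numbers for weaker inhibition. Compound 2 `NC(=O)Cc1cc(=O)oc2cc(OCc3ccccc3)ccc12` gives 200 nM, the lowest of the two numbers. Compound 1 `NC(=O)[C@@H]1CCCN1Cc1cc(=O)oc2cc(OCc3cccc(F)c3)ccc12` gives 850 nM in this assay. These two compounds differ in more than one place, and their values simply stand side by side, with compound 1 sitting higher by more than the usual scatter.

Compound 3 `NC(=O)Cc1cc(=O)oc2cc(OCc3cccc(F)c3)ccc12` is the next compound to be measured. It differs from compound 2 in a single place: fluoro in place of hydrogen on an aromatic carbon. Within the data shown here, no measured pair shows this change on its own; the expectation therefore rests on compound 2. Compound 3 is expected to move little, with a step of no change at the digits printed from compound 2 to compound 3 (within the scatter) that stays within the usual scatter of this assay. Compound 3 is accordingly estimated at 200 nM, with a likely range from 80 nM to 500 nM.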

Compound 3, half-maximal inhibitory concentration: 50 nM
Compound 3: the middle estimate sits 4.0-fold (0.60 log units) above what was measured; the measured number lies below the stated range.
By their numbers in this assay, from the lowest: compound 3; then compound 2; then compound 1.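

In this assay fluoro in place of hydrogen on the benzyl group gives a 4.0-fold lower number from compound 2 to compound 3 (0.60 log units; beyond the scatter) and so shows that this aromatic position responds to a change of a single heavy atom. With the 3-fluorobenzyl group now held constant, carbamoyl in place of 2-carbamoylpyrrolidin-1-yl gives a 17-fold lower number from compound 1 to compound 3 (1.23 log units; beyond the scatter) and marks this change at the chain as the larger of the two steps. Nothing measured here explains either step.

On these data alone, what a chloro or a methoxy group would do in the same place, and whether fluoro matters elsewhere on this aromatic ring, remains open. As far as these compounds go, it is also open how an amine or a carboxylic acid would compare with the carbamoyl group on this chain.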